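The compounds below may be only part of what the source reports. "The series", "measured", "known", "first", "only" and "open" are said of these compounds alone.

Working notes on the series. In a functional assay on A549 cells (Homo sapiens) for antiproliferative activity, read by CCK-8 assay, with a stated time of 72 h (a lower number here means a stronger inhibitor of growth, a higher number a weaker inhibitor of growth), compound 1 (`CCCNS(=O)(=O)c1ccc(Nc2ncc3c(n2)N(C2CCCC2)[C@H](CC)C(=O)N3C)cc1`) gives 563 nM as the only numerical result so far. In this assay, within the data shown here, compound 2 (`CC[C@@H]1C(=O)N(C)c2cnc(-n3ccc4cc(F)ccc43)nc2N1C1CCCC1`) is recorded as "not active" (no number reported) and so stands without a single number, which leaves no measured step from it to any other compound.

Compound 3 (`CC[C@@H]1C(=O)N(C)c2cnc(-n3ccc4cc(C(=O)NCC(C)C)ccc43)nc2N1C1CCCC1`) differs from compound 2 in one place, with isobutylcarbamoyl in place of fluoro on an aromatic carbon of a six-membered aromatic ring of carbon only, part of a fused or bridged system of two rings (isobutylcarbamoyl in place of fluoro on an aromatic carbon). Among the measured compounds shown here, no measured pair isolates this change, so any expectation for it is weakly supported.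

In this assay the expected direction from compound 2 is toward stronger growth inhibition, by a step of unknown size that may only just yield a measurable number. The expected result remains weaker than compound 1 at 563 nM and a second result without a number remains quite possible. Compound 3 is estimated at 3000 nM with an expected range from 500 nM to 20000 nM in this series.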

Compound 3, concentration for 50% growth inhibition: 1730 nM
Compound 3: the middle estimate sits 1.7-fold (0.24 log units) above what was measured; low and high end bracket the measured number.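

In this assay no new step can be read: compound 2 has no number, and compound 3 differs from compound 1 in more than one place. No measured evidence bears on the result. The compounds shown leave open what size of change isobutylcarbamoyl in place of fluoro brings on another matched pair.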